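The source may report more compounds than this note shows. Statements on the series, on what has been measured and on what is new or still open speak of the compounds shown alone.

Measured compounds:
Compound 1 `O=C(Nc1ccc(Oc2ccnc3[nH]ccc23)c(F)c1)c1nn(-c2ccc(Br)cc2)ccc1=O`: in a functional assay on MCF7 cells (Homo sapiens) for cytotoxicity, read by MTT assay, with a stated time of 72 h (on this read-out higher numbers stand for weaker inhibition and lower numbers for stronger inhibition), compound 1 gives 11600 nM.
Compound 2 `O=C(Nc1ccc(Oc2ccnc3[nH]ccc23)c(F)c1)c1nn(-c2ccccc2)ccc1=O`: in this assay compound 2 gives 34900 nM.

Among these two numbers compound 2 stands highest in this assay; its nearest neighbour is compound 1, and the only measured step is a 3.0-fold higher number from compound 1 to compound 2 (0.48 log units; beyond the scatter), a change of bromo to hydrogen on an aromatic carbon. Compound 3 `Cn1ccc2c(Oc3ccc(NC(=O)c4nn(-c5ccccc5)ccc4=O)cc3F)ccnc21` differs from compound 2 by methyl in place of hydrogen on an aromatic nitrogen, a methyl in place of hydrogen on an aromatic nitrogen. Within the data shown here, no measured step touches this position; the step between compound 1 and compound 2 concerns a different ring and does not bear on it. With nothing to anchor a direction, compound 3 is expected to give a number near that of compound 2, with a step of a 1.0-fold higher number from compound 2 to compound 3 (0.00 log units; within the scatter) that is expected to stay within the scatter. The estimate for compound 3 in this assay is 35000 nM, with a range from 12000 nM to 100000 nM.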

Compound 3, half-maximal inhibitory concentration: > 60000 nM
Compound 3: a limit, no number; the forecaster's own chance of this, stated with the estimate: 15%; at least 1.7-fold (0.23 log units) between middle value and limit.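

Among these compounds, until now nothing spoke to the aromatic nitrogen of the five-membered ring, as the only earlier step lay on a different ring. In this assay compound 3 gives > 60000 nM, which is a limit of the assay and not a number. Methyl in place of hydrogen on this nitrogen gives an at least 1.7-fold higher number from compound 2 to compound 3 (0.23 log units; that floor lies within the scatter), so the change brings no stronger inhibition, but its true size cannot be read, and the step is only a floor: the limit of > 60000 nM in this assay, at which 1 of the 3 values shown sits.

As far as these compounds go, how far compound 3 really lies from compound 2 stays open, as does whether an ethyl group or a chain ending in an amine on this nitrogen would behave as methyl does. Also open, from the compounds shown here alone, is whether the bromo of compound 1 would have any effect in a compound carrying methyl on this nitrogen.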